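Swapping phenyl for 2-aminoethyl in compound 2

This account rests on a few compounds, and the source may have more. Where it says the series, first, only, none or still open, it means among the compounds named here.

Compound 1 `Cc1nn(-c2ccccc2)c(S)c1C(=O)c1ccccc1` gives -0.3 in a physicochemical assay for lipophilicity, at pH 7.4, tested at 10 mM; on this read-out higher numbers stand for higher lipophilicity and lower numbers for lower lipophilicity
Compound 2 `Cc1cc(COc2cc(C)nn2-c2ccccc2)n(-c2ccccc2)n1` gives 2.2 in the same measurement
Compound 3 `Cc1cc(CNCc2cc(C)nn2-c2ccccc2)n(-c2ccccc2)n1` gives 5 in the same measurement

Compound 2 stands in the middle of these three, clearly above compound 1 and clearly below compound 3. Compound 4 `Cc1cc(OCc2cc(C)nn2-c2ccccc2)n(CCN)n1` has 2-aminoethyl in place of phenyl on an aromatic nitrogen as its change from compound 2. Going by the values given here, no measured pair shows a change of this kind, so any size given here is only an expectation. A fall beyond the scatter is expected, an estimated a number 1.40 log units lower from compound 2 to compound 4 (beyond the scatter) in this assay for this change. Compound 3 reaches 5 far from the other two, so the range is kept broad. The expected value for compound 4 is 0.8 within an estimated range of -0.2 to 1.8 on this scale.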

Compound 4, distribution coefficient: 5
For compound 4 the middle estimate is 4.20 log units below the measured one, outside the stated range (above it).
By their numbers in this assay, from the lowest: compound 1; then compound 2; then compounds 3 and 4 (each within the scatter of the next).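

In this assay the swap of phenyl for 2-aminoethyl on an aromatic nitrogen gives a number 2.80 log units higher from compound 2 to compound 4 (beyond the scatter) so this position responds strongly to the group it carries. Losing the six-membered aromatic ring and gaining a chain with a hydrogen-bond donor does not bring the number down here. No measurement at hand explains this direction.

The compounds shown leave open whether the rise follows the chain or its amine, and a plain ethyl group or a longer 3-aminopropyl chain on this nitrogen would bear on that question.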